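Thiophen-3-yl for thiophen-2-yl on the saturated ring carbon

A few compounds are considered here, and "the series" means these few. Any claim that something is new, unique, unknown or untested is made for them only; others in the source may bear on it.

Three compounds of the series have numbers in an assay on membranes from HeLa cells for displacement of a labelled ligand from adenosine receptor A3 (Homo sapiens), read by scintillation counting, with a stated time of 180 min, tested at 1 uM; on this read-out higher numbers stand for more inhibition at the one concentration tested (going by the name of the read-out) and lower numbers for less inhibition. Compound 1 `CC1=C(C(=O)CC(C)C)C(c2ccsc2)NC(=O)N1` gives 14% in this assay. Compound 2 `CCNC(=O)C1=C(C)NC(=O)NC1c1ccoc1` gives 1% in this assay, and compound 3 `CCNC(=O)C1=C(C)NC(=O)NC1c1cccs1` gives 4% in this assay. On these three numbers compound 3 sits between the other two: one measured step is a number 3 percentage points higher from compound 2 to compound 3 (within the scatter), and the gap between compound 3 and compound 1, whose number in this assay is 14%, also lies within the usual scatter, so the three numbers cannot be told apart.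

Compound 4 `CCNC(=O)C1=C(C)NC(=O)NC1c1ccsc1` differs from compound 3 in one place: thiophen-3-yl in place of thiophen-2-yl on a saturated ring carbon. For the measured compounds named here, the only measured step with a change at this saturated ring carbon is a number 3 percentage points higher from compound 2 to compound 3 (within the scatter), and that step was within the scatter. It concerns a different exchange and gives no sign that the group at this position moves the read-out in this assay. Going by the values given here, no step between thiophen-2-yl and thiophen-3-yl has been measured anywhere.

The expectation is therefore no step beyond the scatter: for compound 4 the estimated step is a number 1 percentage points higher from compound 3 to compound 4 (within the scatter). Compound 4 is expected to give about 5% in this assay, with a range from -6% to 16%.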

Compound 4, a percentage reported as inhibition, at one concentration (the size of the read-out at that concentration, not a potency): 1%
Compound 4: middle estimate off by 4 percentage points, on the high side; the measured number falls inside the stated range.
By their numbers in this assay, from the lowest: compounds 2, 4, 3 and 1 (each within the scatter of the next, the first and the last beyond it).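

In this assay the direct exchange of thiophen-2-yl for thiophen-3-yl on the saturated ring carbon gives a number 3 percentage points lower from compound 3 to compound 4 (within the scatter) and the exchange of furan-3-yl for thiophen-3-yl gives no change at the digits printed from compound 2 to compound 4 (within the scatter) so, with the ethylcarbamoyl group held, furan-3-yl, thiophen-2-yl and thiophen-3-yl cannot be told apart at this position. For the compounds shown here, the first step beyond the scatter lies at the other place, the carbonyl carbon: with thiophen-3-yl held, ethylamino in place of isobutyl gives a number 13 percentage points lower from compound 1 to compound 4 (beyond the scatter) and so marks this place, not the saturated ring carbon, as the one where the read-out has moved so far. No measurement at hand gives a reason for either result.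

Still open, from the compounds shown here alone, is whether a phenyl ring or a longer chain on the saturated ring carbon would move the number in this assay at all, given that only five-membered aromatic rings appear there. Also open, going by these compounds, is whether the step at the carbonyl carbon holds with thiophen-2-yl or furan-3-yl on the ring, and what a methoxy group or a longer branched chain would give in place of isobutyl.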